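A Nitro Analogue in a Weakly Cytotoxic Coumarin Series

The source may hold more compounds than are shown below. What is called first, only, known or untested is meant among the compounds shown, and "the series" means these compounds.

Measured compounds:
Compound 1 `C#CCOc1ccc2oc(=O)ccc2c1` – for compound 1 the result in a functional assay on COLO 205 cells (Homo sapiens) for cytotoxicity, read by MTT assay, with a stated time of 48 h (on this read-out higher numbers stand for weaker inhibition and lower numbers for stronger inhibition), is "not determined" (no result reported).
Compound 2 `O=c1ccc2cc(OCc3cc(-c4ccc5ccccc5c4)no3)ccc2o1` – compound 2 gives 48700 nM in this assay.
Compound 3 `COc1cccc(-c2cc(COc3ccc4oc(=O)ccc4c3)on2)c1` – for compound 3 the result in this assay is "not determined" (no result reported).

Compound 3 carries a methoxy on a six-membered aromatic ring of carbon only, attached through a five-membered ring and a linker to the shared core. Where compound 3 stands cannot be told from numbers: no result was reported for it, and the same holds for compound 1. For the measured compounds named here, the one number in the set comes from compound 2, which sits at a high concentration on this read-out, meaning weak inhibition.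

Compound 4 `O=c1ccc2cc(OCc3cc(-c4cccc([N+](=O)[O-])c4)no3)ccc2o1` follows from compound 3 by one change: nitro in place of methoxy on an aromatic carbon. Going by the values given here, no measured pair shows what such a swap does here, so the expectation rests on compound 2 alone, which suggests that members inhibit only weakly. A step of modest size in either direction, or none beyond the scatter, is the most that can be expected.

For compound 4 the expected value in this assay is 40000 nM, with a range from 10000 nM to 150000 nM.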

Compound 4, half-maximal inhibitory concentration: 48300 nM
Beside the measured number, compound 4's estimate is 1.2-fold (0.08 log units) below it, within the range that was stated.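

No step can be read between compound 3 and compound 4: compound 3 has no single number in this assay. The compounds shown leave open what nitro in place of methoxy does to cytotoxicity. Nothing shown offers an explanation for the result of compound 4.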